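Volume of distribution notes on compounds 1 to 4

A few compounds are considered here, and "the series" means these few. Any claim that something is new, unique, unknown or untested is made for them only; others in the source may bear on it.

Measured in an ADME assay (Rattus norvegicus, strain Wistar Han) for pharmacokinetics; on this read-out higher numbers stand for wider distribution into tissues and lower numbers for narrower distribution:
- compound 1 `CCn1c(-c2cnc(C)nc2)nc2c(N[C@H]3CCN(C(=O)N4CC(OC)C4)C3)ncnc21` gives 0.7 L/kg
- compound 2 `CCn1c(-c2cnc(C)nc2)nc2c(N[C@H]3CCN(C(=O)C4CC4)C3)ncnc21` gives 1 L/kg
- compound 3 `CCn1c(-c2ccc(C(F)(F)F)nc2)nc2c(O[C@H]3CCN(C(=O)C4CC4)C3)ncnc21` gives 0.7 L/kg

Compound 1 and compound 2 share a core and differ only by 3-methoxyazetidin-1-yl in place of cyclopropyl on a carbonyl carbon; this change gave a 1.4-fold lower number from compound 2 to compound 1 (0.15 log units; within the scatter). Compound 3 differs from compound 2 in more than one place, and the difference between the two cores is not broken down here. The values of compound 3 and compound 1 are level at the digits given, and compound 2 sits within the scatter of both.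

Compound 4 `CCn1c(-c2ccc(C(F)(F)F)nc2)nc2c(O[C@H]3CCN(C(=O)N4CC(OC)C4)C3)ncnc21` is not yet measured in this assay. It differs from compound 3 by 3-methoxyazetidin-1-yl in place of cyclopropyl on a carbonyl carbon, the same change as from compound 2 to compound 1, at a place described in the same words. For the measured compounds named here, the step is expected to be about the size of the earlier one, namely a 1.4-fold lower number from compound 3 to compound 4 (0.15 log units; within the scatter), because a 1.4-fold lower number from compound 2 to compound 1 (0.15 log units; within the scatter) is the only measured precedent for this change. Compound 4 is therefore estimated at 0.5 L/kg, with a range from 0.3 L/kg to 0.9 L/kg.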

Compound 4, volume of distribution: 0.2 L/kg
The estimate for compound 4 lay 2.5-fold (0.40 log units) above the measured number; the whole stated range lies above it.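

In this assay, 3-methoxyazetidin-1-yl in place of cyclopropyl on a carbonyl carbon gives a 3.5-fold lower number from compound 3 to compound 4 (0.54 log units; beyond the scatter) on the core of compound 3. For the compounds shown here, only this step lies beyond the scatter, yet the two steps for the same change cannot be told apart: the same change on two cores in this assay, a 1.4-fold lower number (0.15 log units; within the scatter) from compound 2 to compound 1 and a 3.5-fold lower number (0.54 log units; beyond the scatter) from compound 3 to compound 4, 2.5-fold (0.39 log units) apart, within the scatter of two such steps. On these two pairs the change therefore carries from one core to the other with no resolved difference in size, but two pairs do not establish a fixed step size or show that the core has no influence.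

From the compounds shown here alone, the two cores differ in more than one place, so the part of the core that might matter remains open. Also open, going by these compounds, is how a dimethylamino group or a longer alkyl chain on the same carbonyl carbon would behave on these cores.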